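The source may report more compounds than this note shows. Statements on the series, on what has been measured and on what is new or still open speak of the compounds shown alone.

Measured in a functional assay on A549 cells (Homo sapiens) for inhibition, read by MTT assay, with a stated time of 72 h; on this read-out lower numbers stand for stronger inhibition and higher numbers for weaker inhibition:
Compound 1 `COc1cc2c(Oc3ccc(NC(=O)c4nn(-c5ccccc5C)cc(C)c4=O)cc3)ccnc2cc1OCCCC(=O)NO` gives 4460 nM
Compound 2 `COc1cc2c(Oc3ccc(NC(=O)c4nn(-c5ccccc5)ccc4=O)cc3)ccnc2cc1OCCCC(=O)NO` gives 9260 nM
Compound 3 `COc1cc2c(Oc3ccc(NC(=O)c4nn(-c5ccccc5F)cc(C)c4=O)cc3)ccnc2cc1OCCCC(=O)NO` gives 3920 nM

Compound 1 stands second highest of the three numbers. Its nearest neighbour is compound 3, reached by a 1.1-fold lower number from compound 1 to compound 3 (0.06 log units; within the scatter). Within the data shown here, compound 2 is furthest; the values of compound 1 and compound 2 differ by more than the scatter, no step between them being computed.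

Compound 4 `COc1cc2c(Oc3ccc(NC(=O)c4nn(-c5ccccc5C)cc(C)c4=O)cc3)ccnc2cc1OCCCCCCC(=O)NO` is not yet measured. It differs from compound 1 in one place: 3-(hydroxycarbamoyl)propyl in place of hydroxycarbamoyl on a saturated chain carbon, three bonds along the chain from an oxygen on an aromatic ring. Among the measured compounds shown here, no measured step bears on this change; the only step in hand, a 1.1-fold lower number from compound 1 to compound 3 (0.06 log units; within the scatter), alters a different part of the molecule. With nothing to guide direction, no step beyond the scatter is expected. For compound 4 the estimate in this assay is 4000 nM, in the range 1300 nM to 12000 nM, which means an expected step of a 1.1-fold lower number from compound 1 to compound 4 (0.05 log units; within the scatter).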

Compound 4, half-maximal inhibitory concentration: 3130 nM
Compound 4: middle estimate off by 1.3-fold (0.11 log units), on the high side; the range from low to high includes it.
By their numbers in this assay, from the lowest: compounds 4, 3 and 1 (each within the scatter of the next); then compound 2.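

In this assay, 3-(hydroxycarbamoyl)propyl in place of hydroxycarbamoyl on a saturated chain carbon, three bonds along the chain from an oxygen on an aromatic ring, gives a 1.4-fold lower number from compound 1 to compound 4 (0.15 log units; within the scatter), so this read-out does not separate the two chain lengths. Among these compounds, the only earlier step altered a different part of the molecule, so this is the sole reading on the chain. No evidence on hand bears on this result.

Still open, going by these compounds, is whether a carboxylic acid or an amine in place of hydroxycarbamoyl would hold the value. Also open, on these data alone, is whether a longer chain would do so.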